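The source may hold more compounds than are shown below. What is called first, only, known or untested is meant among the compounds shown, and "the series" means these compounds.

Measured so far in a functional assay on A-375 cells (Homo sapiens) for antiproliferative activity, read by CCK-8 assay, with a stated time of 72 h, tested at 8 uM; on this read-out higher numbers stand for a stronger effect at the one concentration tested and lower numbers for a weaker effect:

- compound 1 `Nc1ccccc1NC(=O)c1ccc(CSC(=S)N2CCN(Cc3ccccn3)CC2)cc1`: 82.4%
- compound 2 `N#Cc1ccc(N2CCN(C(=S)SCc3ccc(C(=O)Nc4ccccc4N)cc3)CC2)cc1`: 62.9%

For the measured compounds named here, compound 2 gives the lower of the two numbers in this assay, and the one step measured leads to it: a number 19.5 percentage points lower from compound 1 to compound 2 (beyond the scatter). Going by the values given here, that step exchanges the whole group on the amine nitrogen in the ring, and it is the only comparison in hand.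

Compound 3 `Cc1ccc(N2CCN(C(=S)SCc3ccc(C(=O)Nc4ccccc4N)cc3)CC2)cc1` differs from compound 2 as follows: methyl in place of cyano on an aromatic carbon. The measured step from compound 1 to compound 2 does not bear on this change directly, since it swaps (pyridin-2-yl)methyl for 4-cyanophenyl rather than altering a substituent on a phenyl already attached to that nitrogen. Among the compounds with values here, no measured pair shows cyano against methyl on that aromatic carbon. With nothing in hand that speaks to the exchange, the expected step in this assay is a number 0.9 percentage points lower from compound 2 to compound 3 (within the scatter), that is none beyond the scatter, and the uncertainty is wider than for a change already sampled.

The estimate for compound 3 is therefore 62%, expected to lie between 44% and 78%.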

Compound 3, a percentage reported as inhibition, at one concentration (the size of the read-out at that concentration, not a potency): 26.4%
For compound 3 the middle estimate is 35.6 percentage points above the measured one, and the stated range ends above it.
By their numbers in this assay, from the lowest: compound 3; then compound 2; then compound 1.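

In this assay the group on the aromatic carbon para to a large group is not a neutral detail: methyl in place of cyano gives a number 36.5 percentage points lower from compound 2 to compound 3 (beyond the scatter) and so changes the read-out well beyond the usual scatter. The exchange of (pyridin-2-yl)methyl on the ring nitrogen also reads differently now, since the entry of 4-methylphenyl gives a number 56 percentage points lower from compound 1 to compound 3 (beyond the scatter) and the result of that exchange therefore depends on the substituent carried by the entering phenyl group. No measurement in hand accounts for the difference between cyano and methyl at this place.

The compounds shown leave open whether the higher number of compound 2 belongs to cyano specifically or would also appear with other groups at this place, such as trifluoromethyl, a carboxylic acid, an amine or a simple chlorine atom. They also leave open whether an unsubstituted phenyl group on the ring nitrogen would stand nearer to compound 2 or to compound 3, which would show which of the two substituents moves the read-out.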